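The source may report more compounds than this note shows. Statements on the series, on what has been measured and on what is new or still open speak of the compounds shown alone.

The measured compounds:
compound 1, `CCOC(=O)C1=C(Nc2ccccc2)S/C(=C\c2ccc(C(=O)O)cc2)C1=O`, with 11.6%
compound 2, `CCOC(=O)C1=C(Nc2ccccc2)S/C(=C\c2cccc(C(=O)O)c2)C1=O`, with < 10%

In a functional assay on A549 cells (Homo sapiens) for inhibition, read by MTT assay, with a stated time of 72 h, tested at 10 uM (a higher number here means more inhibition at the concentration tested (going by the name of the read-out), a lower number less inhibition), compound 1 gives 11.6%. Compound 2 sits at the limit of < 10% in this assay, at which 1 of the 2 values shown sits, so for compound 2 the read-out in this assay is a limit and not a number. Among the measured compounds shown here, the one measured step is a number at least 1.6 percentage points lower from compound 1 to compound 2 (that floor lies within the scatter), and with a limit at its lower end it fixes only a floor for the step, not its true size.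

Compound 3, `CCOC(=O)C1=C(Nc2ccccc2)S/C(=C\c2cccnc2)C1=O`, has not yet been measured in this assay. It differs from compound 2 by pyridin-3-yl in place of 3-carboxyphenyl on a double-bonded chain carbon bound to a double-bonded ring carbon. For the measured compounds named here, no measured step covers this exchange; the only step on hand moves a carboxylic acid from one position of the phenyl ring to another, and both of its compounds give low read-outs. On the numbers shown there is thus no basis for a step beyond the scatter in either direction. The expected step is a step that the limit leaves unreadable from compound 2 to compound 3. The estimate for compound 3 is 8%, with a range from 0% to 18%, and a fair chance that this assay again reports only a limit.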

Compound 3, a percentage reported as inhibition, at one concentration (the size of the read-out at that concentration, not a potency): < 10%
Compound 3 was reported as a limit; the forecaster's own chance of this, stated with the estimate: 55%; the middle value does not contradict the limit.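

In this assay compound 3 gives < 10%, which is a limit and not a number. The exchange of 3-carboxyphenyl for pyridin-3-yl has a limit at both ends, so its size cannot be read: the limit of < 10% in this assay, at which 2 of the 3 values shown sit.

The exchange of 4-carboxyphenyl for pyridin-3-yl gives a number at least 1.6 percentage points lower from compound 1 to compound 3 (that floor lies within the scatter), so this comparison also shows no change beyond the scatter. What the new compound adds is that, at this place on a double-bonded chain carbon bound to a double-bonded ring carbon, a ring without a carboxylic acid also leaves the read-out at the limit, as the two acids did not clearly differ from one another.

The compounds shown leave open whether an amine or a hydroxyl group on the aromatic ring at this place would give a read-out clearly clear of the limit in this assay. They also leave open how compound 2 and compound 3 truly compare, and whether a change elsewhere on the shared core would matter more than the exchanges seen here.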